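The compounds below may be only part of what the source reports. "The series", "measured", "known", "first", "only" and "open" are said of these compounds alone.

Measured compounds:
- compound 1, `NC(=O)c1cnc(C(=O)CCc2ccc(Oc3ccccc3)cc2)o1`: 6.6 nM
- compound 2, `CS(=O)(=O)c1cnc(C(=O)CCc2ccc(-c3ccccc3)cc2)o1`: 1.2 nM
- compound 3, `COC(=O)c1cnc(C(=O)CCc2ccc(Oc3ccccc3)cc2)o1`: 1.7 nM

All three numbers come from an assay for inhibition of Fatty-acid amide hydrolase 1 (Rattus norvegicus); on this read-out higher numbers stand for weaker inhibition and lower numbers for stronger inhibition. Compound 3 stands second highest of the three; its nearest neighbour is compound 2, whose number is lower but within the usual scatter, so no order between the two can be claimed, and compound 1 sits furthest away with a higher number beyond the scatter.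

The next compound, compound 4, `O=C(CCc1ccc(Oc2ccccc2)cc1)c1ncc(C(F)(F)F)o1`, is not yet measured. It differs from compound 3 in one place: trifluoromethyl in place of methoxycarbonyl on an aromatic carbon.

For the measured compounds named here, only one measured step bears on this change, because it also alters the group on the same aromatic carbon of the shared core: a 3.9-fold lower number from compound 1 to compound 3 (0.59 log units; beyond the scatter). That step was modest, and it only swapped one part of a carbonyl-bearing group for another, whereas the move to compound 4 removes the carbonyl group entirely and puts trifluoromethyl in its place. Going by the values given here, no measured pair shows what such a removal does here. A step of similar modest size is therefore expected in this assay, with its direction left open, and a change within the scatter is entirely possible.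

For compound 4 in this assay the estimate is 4 nM, with a range from 1.2 nM to 13 nM, which means an expected step of a 2.4-fold higher number from compound 3 to compound 4 (0.37 log units; beyond the scatter).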

Compound 4, inhibition constant: 2 nM
The estimate for compound 4 lay 2.0-fold (0.30 log units) above the measured number, within the range that was stated.
By their numbers in this assay, from the lowest: compounds 2, 3 and 4 (each within the scatter of the next); then compound 1.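

In this assay, the position on the aromatic carbon next to the ring oxygen does not depend on a carbonyl group: compound 4, with trifluoromethyl and no hydrogen-bond acceptors in that group, cannot be told apart from compound 3, with methoxycarbonyl and its two acceptors (a 1.2-fold higher number from compound 3 to compound 4 (0.07 log units; within the scatter)). The earlier compounds shown here only compared two carbonyl-bearing groups, so they could not show this. Carbamoyl in compound 1 now stands apart from both replacements, one keeping a carbonyl and one losing it (a 3.3-fold lower number from compound 1 to compound 4 (0.52 log units; beyond the scatter)), although nothing measured here explains why these groups compare as they do.

Still open, going by these compounds, is how this position responds to groups with neither fluorine nor a carbonyl, such as a nitrile, a methyl group or a bare hydrogen, or to a charged group such as a carboxylic acid. Compound 2 carries a methylsulfonyl group but also differs at the far end of its chain, so whether that group matches trifluoromethyl on the same chain remains unsettled.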